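This account rests on a few compounds, and the source may have more. Where it says the series, first, only, none or still open, it means among the compounds named here.

Compound 1 `COc1ccc(-c2cc(N3CCC(CNS(N)(=O)=O)CC3)ncn2)cc1` gives 35300 nM in a functional assay on MCF7 cells (Homo sapiens) for antiproliferative activity, read by sulforhodamine B assay, with a stated time of 48 h (a lower number here means a stronger inhibitor of growth, a higher number a weaker inhibitor of growth), the lowest of the three numbers shown, though all three lie within the scatter of one another. Compound 2 `NS(=O)(=O)NCC1CCN(c2cc(-c3cccc(Cl)c3)ncn2)CC1` gives 47100 nM and compound 3 `NS(=O)(=O)NCC1CCN(c2cc(-c3ccccc3Cl)ncn2)CC1` gives 62400 nM in this assay. The steps are small: a 1.3-fold higher number from compound 1 to compound 2 (0.13 log units; within the scatter), a 1.8-fold higher number from compound 1 to compound 3 (0.25 log units; within the scatter) and a 1.3-fold higher number from compound 2 to compound 3 (0.12 log units; within the scatter), each within the scatter. Compound 4 `COc1ccc(-c2cc(N3CCC(CCNS(N)(=O)=O)CC3)ncn2)cc1` differs from compound 1 by (sulfamoylamino)methyl in place of sulfamoylamino on a saturated chain carbon bound to a saturated ring carbon. None of the measured steps touches this chain; all three alter the aryl group, and all lie within the scatter, so the change in compound 4 has no precedent among these compounds. Compound 4 is therefore expected to show a step of a 1.1-fold higher number from compound 1 to compound 4 (0.03 log units; within the scatter), with no direction beyond the scatter. Compound 4 is estimated at 38000 nM, with a range from 15000 nM to 95000 nM.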

Compound 4, concentration for 50% growth inhibition: 56600 nM
Estimate against measurement, compound 4: 1.5-fold (0.17 log units) below; measured number inside the range.
By their numbers in this assay, from the lowest: compounds 1, 2, 4 and 3 (each within the scatter of the next).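

In this assay, the chain change gives a step of a 1.6-fold higher number from compound 1 to compound 4 (0.21 log units; within the scatter) and is the only step shown at this saturated chain carbon. It shows that (sulfamoylamino)methyl in place of sulfamoylamino, like the earlier aryl changes, stays within the scatter, so the chain gives no readable preference between the two. No evidence is available that bears on this result. On these data alone, whether a longer chain, or an amine or a carboxylic acid in place of sulfamoylamino, would move the number beyond the scatter remains open. So does whether this chain change would behave alike with 3-chlorophenyl or 2-chlorophenyl on the core.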